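The source may report more compounds than this note shows. Statements on the series, on what has been measured and on what is new or still open speak of the compounds shown alone.

Compound 1 `Cc1ccc(-c2nc3ccccc3s2)cc1NC(=O)c1cc([N+](=O)[O-])c(N(C)C)cc1Cl`: > 25000 nM
Compound 2 `O=C(Nc1ccc(-c2nc3ccccc3s2)cc1)c1cc([N+](=O)[O-])ccc1Cl`: > 27000 nM
Compound 3 `O=C(Nc1cccc(-c2ccccc2)c1)c1cc([N+](=O)[O-])ccc1Cl`: > 27000 nM

All three compounds were tested in an ADME assay on Raji cells (Homo sapiens) for cytotoxicity, with a stated time of 72 h (on this read-out lower numbers stand for an effect already at smaller amounts and higher numbers for an effect only at larger amounts of compound), and each reading is a limit of the assay, not a number. Compound 3 stands at the limit of > 27000 nM in this assay, at which 2 of the 3 values shown sit. Compound 4 `O=C(Nc1cccc(-c2nc3ccccc3[nH]2)c1)c1cc([N+](=O)[O-])ccc1Cl` carries 1H-benzimidazol-2-yl in place of phenyl on an aromatic carbon, meta to a large group (1H-benzimidazol-2-yl in place of phenyl on an aromatic carbon). For the measured compounds named here, no measured pair shows what a single change does here, so in this assay no direction is expected and no step beyond the usual scatter. This expectation rests on compound 3, whose reading of > 27000 nM is a limit. The expected change is a number no higher from compound 3 to compound 4 (the limit leaves the size open). Compound 4 is estimated at 27000 nM, with an expected range from 9000 nM to 60000 nM.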

Compound 4, half-maximal effective concentration: 20700 nM
For compound 4 the middle estimate is 1.3-fold (0.12 log units) above the measured one, and the stated range covers the measured number.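

In this assay compound 4 gives 20700 nM as the first true number among the compounds shown. Compound 3 stands only at a limit of the assay, not at a number: the limit of > 27000 nM in this assay, at which 2 of the 4 values shown sit. From the compounds shown here alone, putting 1H-benzimidazol-2-yl in place of phenyl gives an at least 1.3-fold lower number from compound 3 to compound 4 (0.11 log units; that floor lies within the scatter) and so brings the reading within the measurable range, while the full size of the step stays unknown.

Going by these compounds, whether an amine or a carboxylic acid on this aromatic carbon would also give a number remains open. So does whether the same exchange acts alike on the other compounds.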